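A few compounds are considered here, and "the series" means these few. Any claim that something is new, unique, unknown or untested is made for them only; others in the source may bear on it.

Measured compounds in this assay:
compound 1 `CCc1ccc2ncn(-c3ccnc(N)n3)c2c1` gives 79400 nM
compound 2 `C=CC(=O)NCCCc1ccc2ncn(-c3ccnc(N)n3)c2c1` gives 501000 nM
compound 3 `C=Cc1cc(C#Cc2ccc3ncn(-c4ccnc(N)n4)c3c2)ccn1` gives 20000 nM

All three numbers come from an assay on Sf9 cells for inhibition of mitogen-activated protein kinase kinase kinase 14 variant S549D (Homo sapiens), with a stated time of 30 min, in the presence of a further agent that is not named here; on this read-out higher numbers stand for weaker inhibition and lower numbers for stronger inhibition. Compound 3 stands lowest of the three; compound 1 is nearest to it and compound 2 furthest, both steps beyond the scatter. Going by the values given here, the only step between compounds that differ in one place is a 6.3-fold higher number from compound 1 to compound 2 (0.80 log units; beyond the scatter), which concerns the saturated chain on the shared core and says nothing about the group carried on the triple bond.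

Compound 4 `C#Cc1cncc(C#Cc2ccc3ncn(-c4ccnc(N)n4)c3c2)c1` is the next compound for this assay. Against compound 3 the change is a group of 8 heavy atoms (7 carbon, 1 nitrogen; one six-membered aromatic ring with 1 hetero atom) in place of a group of 8 heavy atoms (7 carbon, 1 nitrogen; one six-membered aromatic ring with 1 hetero atom), on a triple-bonded carbon. The leaving and entering groups match in heavy-atom count, ring size and ring nitrogen count; the leaving group carries its one double bond outside aromatic rings, the entering group its one triple bond outside aromatic rings.

Among the compounds with values here, no measured step touches this end of the molecule, so there is no basis from the series for a direction. The same-sized aromatic group on the same triple-bonded carbon leads to the expectation of a step no larger than the scatter, a 1.1-fold higher number from compound 3 to compound 4 (0.04 log units; within the scatter). Compound 4 is therefore estimated at 22000 nM, with a range from 5000 nM to 100000 nM.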

Compound 4, half-maximal inhibitory concentration: 63100 nM
The estimate for compound 4 lay 2.9-fold (0.46 log units) below the measured number; the range from low to high includes it.
By their numbers in this assay, from the lowest: compound 3; then compounds 4 and 1 (each within the scatter of the next); then compound 2.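

Going by these compounds alone, on the triple-bonded carbon whose other neighbours are triple-bonded carbon, a 3.2-fold higher number from compound 3 to compound 4 (0.50 log units; beyond the scatter) in this assay gives the first reading at this end of the molecule, as 2-vinylpyridin-4-yl gives way to a group with the same heavy-atom count, ring size, ring nitrogen count and hydrogen-bond counts. Matching on these counts therefore does not make the two groups interchangeable here: the number still moves beyond the scatter, with one double bond outside aromatic rings replaced by one triple bond outside aromatic rings and the atoms arranged differently on the group. No measurement available here bears on the reason for this step.

The compounds shown leave open whether the step follows from the change of double to triple bond or from the different arrangement of the entering group, since the two differences arrive together in a single pair. Also open, from the compounds shown here alone, is how this end of the molecule would respond to a group of another kind on the six-membered aromatic ring, such as a primary amine or a carboxylic acid in place of the vinyl group, or to a longer chain there.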